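Aryl sulfamates on the shared core: tertiary amine variation

The compounds below may be only part of what the source reports. "The series", "measured", "known", "first", "only" and "open" are said of these compounds alone.

Measured so far:
compound 1, `CCN(Cc1ccncc1)c1cccc(C(=O)N2CCc3ccc(OS(N)(=O)=O)cc3C2)c1`, 33.3%
compound 2, `CN(CCN1CCCCC1)c1ccc(C(=O)N2CCc3ccc(OS(N)(=O)=O)cc3C2)cc1`, 0.3%

In an assay on HEK293 cells for inhibition of Steryl-sulfatase (Homo sapiens), tested at 0.1 uM (on this read-out higher numbers stand for a stronger effect at the one concentration tested and lower numbers for a weaker effect), compound 1 gives 33.3% and stands highest of the two numbers recorded. Compound 2 gives 0.3% in this assay, a number far enough below compound 1 to lie beyond the scatter. For the measured compounds named here, no pair of measured compounds differs in a single place, so no step has been quantified; the two values simply show that the substitution pattern on the aryl amide matters for the read-out.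

Compound 3, `NS(=O)(=O)Oc1ccc2c(c1)CN(C(=O)c1cccc(N3CCc4ccccc4C3)c1)CC2`, remains to be measured in this assay. It differs from compound 1 in one place: 1,2,3,4-tetrahydroisoquinolin-2-yl in place of ethyl((pyridin-4-yl)methyl)amino on an aromatic carbon. The group that leaves and the group that enters are both tertiary amines attached at the same aromatic carbon, meta to a large group, and the count of heavy atoms is the same for both. Going by the values given here, since no measured step of this kind exists, the direction is open; a modest step, not clearly beyond the scatter, is expected a number 4.7 percentage points higher from compound 1 to compound 3 (within the scatter), and compound 3 is estimated at 38%, within 10% to 70%.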

Compound 3, a percentage reported as inhibition, at one concentration (the size of the read-out at that concentration, not a potency): 24.1%
For compound 3 the middle estimate is 13.9 percentage points above the measured one; the range from low to high includes it.
By their numbers in this assay, from the lowest: compound 2; then compounds 3 and 1 (each within the scatter of the next).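

In this assay, for the compounds shown here, 1,2,3,4-tetrahydroisoquinolin-2-yl in place of ethyl((pyridin-4-yl)methyl)amino on an aromatic carbon, meta to a large group, gives a number 9.2 percentage points lower from compound 1 to compound 3 (within the scatter), the first step that changes a single place. At this position and at the one concentration tested, the read-out therefore does not separate the two tertiary amines, although the entering group has a six-membered aromatic ring of carbon only where the leaving group has a six-membered aromatic ring with 1 hetero atom. No measurement on hand bears on why these two groups read alike.

Open, as far as these compounds go, is how a morpholin-4-yl group, a plain dimethylamino group or a carboxylic acid on the same aromatic carbon would read in this assay, and whether any of them would move the number beyond the scatter from compound 1. Compound 2 differs from compound 1 and from compound 3 in more than one place, so which of its changes accounts for its low number also stays open.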